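The source may hold more compounds than are shown below. What is called first, only, known or untested is meant among the compounds shown, and "the series" means these compounds.

Of the compounds shown here, three of a shared core have been measured. In a functional assay on A549 cells (Homo sapiens) for cytotoxicity, read by MTT assay, with a stated time of 72 h (a higher number here means a weaker inhibitor, a lower number a stronger inhibitor), compound 1 `Cc1ccc(-c2ccnc(C(=O)Nc3ccc(Oc4ccnc5[nH]ccc45)cc3)n2)cc1` gives 2380 nM. Compound 2 `O=C(Nc1ccc(Oc2ccnc3[nH]ccc23)cc1)c1nccc(-c2cccc(Cl)c2)n1` gives 4120 nM in this assay; the step of a 1.7-fold higher number from compound 1 to compound 2 (0.24 log units; within the scatter) stays inside the scatter, so the two numbers cannot be told apart. Compound 3 `Cc1ccc(-c2ccnc(C(=O)Nc3ccc(Oc4ccnc5[nH]ccc45)c(F)c3)n2)cc1` gives 1150 nM in this assay; the step of a 2.1-fold lower number from compound 1 to compound 3 (0.32 log units; beyond the scatter) is modest but does lie beyond the scatter. Compound 3 thus holds the lowest number of the three, with compound 1 nearest and compound 2 furthest, and both gaps are beyond the scatter, so among these three it is the strongest inhibitor.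

Compound 4 `O=C(Nc1ccc(Oc2ccnc3[nH]ccc23)c(F)c1)c1nccc(-c2cccc(Cl)c2)n1` differs from compound 3 in one place: 3-chlorophenyl in place of 4-methylphenyl on an aromatic carbon. Within the data shown here, the only measured step that bears on this change is a 1.7-fold higher number from compound 1 to compound 2 (0.24 log units; within the scatter), a shift toward a higher number that remained within the scatter. Carrying the same change onto compound 3, the expectation is a step of a 1.7-fold higher number from compound 3 to compound 4 (0.23 log units; within the scatter), a small rise in the number that may well not exceed the scatter. On that basis compound 4 is estimated to give 1950 nM in this assay, with a likely range from 900 nM to 4500 nM.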

Compound 4, half-maximal inhibitory concentration: 450 nM
Estimate against measurement, compound 4: 4.3-fold (0.64 log units) above, outside the stated range (below it).
By their numbers in this assay, from the lowest: compound 4; then compound 3; then compounds 1 and 2 (each within the scatter of the next).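

The swap of 4-methylphenyl for 3-chlorophenyl on this aromatic carbon, which had looked neutral, proves to depend on the core that carries it: with the fluoro present it gives a 2.6-fold lower number from compound 3 to compound 4 (0.41 log units; beyond the scatter), and the earlier step without the fluoro does not predict this: the same change on two cores in this assay, a 1.7-fold higher number (0.24 log units; within the scatter) from compound 1 to compound 2 and a 2.6-fold lower number (0.41 log units; beyond the scatter) from compound 3 to compound 4, 4.4-fold (0.65 log units) apart, beyond the scatter of two such steps The fluoro likewise counts for more with 3-chlorophenyl in place, where it gives a 9.2-fold lower number from compound 2 to compound 4 (0.96 log units; beyond the scatter), than it did with 4-methylphenyl: the same change on two cores in this assay, a 2.1-fold lower number (0.32 log units; beyond the scatter) from compound 1 to compound 3 and a 9.2-fold lower number (0.96 log units; beyond the scatter) from compound 2 to compound 4, 4.4-fold (0.65 log units) apart, beyond the scatter of two such steps In this assay, then, these two changes do not act independently across the four compounds, and neither step can be carried from one core to the other.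

The compounds shown leave open whether this dependence belongs to the chlorine itself or to its place on the phenyl ring, a question that 4-chlorophenyl and 3-methylphenyl on the same fluoro-bearing core would address. They also leave open whether a 3-methoxyphenyl or 3-bromophenyl group would pair with the fluoro in the same way, and whether a chloro in place of that fluoro would do so.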